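Thiophene sulfonamide catechols: three limits and one expectation

This account rests on a few compounds, and the source may have more. Where it says the series, first, only, none or still open, it means among the compounds named here.

Compound 1, `CC(C)c1ccc(Oc2ccc(O)c(O)c2)c(-c2ccsc2S(=O)(=O)NCCNC(=S)Nc2cc(C(F)(F)F)cc(C(F)(F)F)c2)c1`, in a functional assay on HeLa cells (Homo sapiens) for inhibition, read by CCK-8 assay, with a stated time of 48 h (on this read-out higher numbers stand for weaker inhibition and lower numbers for stronger inhibition), gives only a limit, > 20000 nM.
Compound 2, `O=C(NCCNS(=O)(=O)c1sccc1-c1ccccc1Oc1ccc(O)c(O)c1)Nc1cc(C(F)(F)F)cc(C(F)(F)F)c1`, in this assay gives only a limit, > 50000 nM.
Compound 3, `CC(C)c1ccc(Oc2ccc(O)c(O)c2)c(-c2ccsc2S(=O)(=O)NCCNC(=O)Nc2cc(C(F)(F)F)cc(C(F)(F)F)c2)c1`, in this assay gives only a limit, > 50000 nM.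

None of the three measured compounds gives a number in this assay; each value is a limit of the assay. Two of the three sit at the limit of > 50000 nM in this assay, at which 2 of the 3 values shown sit, and one sits at the limit of > 20000 nM in this assay, at which 1 of the 3 values shown sits. Among the compounds with values here, the one change that can be followed between measured compounds is hydrogen in place of isopropyl on an aromatic carbon, and the step it makes is a step that the two limits leave unreadable from compound 3 to compound 2, so its size cannot be read from these data. Compound 1 and compound 3 differ in more than one place, and the difference between the two cores is not broken down here.

The unmeasured compound 4, `O=S(=O)(NCCNC(=S)Nc1cc(C(F)(F)F)cc(C(F)(F)F)c1)c1sccc1-c1ccccc1Oc1ccc(O)c(O)c1`, comes from compound 1 by hydrogen in place of isopropyl on an aromatic carbon, the same change as that from compound 3 to compound 2, with the same surroundings at the place of change. For compound 4 in this assay the account expects a step that the limit leaves unreadable from compound 1 to compound 4, which rests on compound 1 standing at a limit, > 20000 nM, and on the measured pair, compound 3 and compound 2, both lying at limits. Compound 4 is therefore expected to give 60000 nM, most likely reported again as a limit, with the range 20000 nM to 200000 nM.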

Compound 4, half-maximal inhibitory concentration: > 50000 nM
Compound 4: only a limit was reported; the forecaster's own chance of this, stated with the estimate: 85%; the middle value is on the limit's open side.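

In this assay compound 4 gives only a limit, > 50000 nM. Compound 1 also stands at a limit, so no step can be read from compound 1 to compound 4, and hydrogen in place of isopropyl has no readable size here. The compounds shown leave open what actual value any of them would give in this assay, and whether this change alters inhibition at all.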